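This account rests on a few compounds, and the source may have more. Where it says the series, first, only, none or still open, it means among the compounds named here.

Within the data shown here, in a functional assay on HL-60 cells (Homo sapiens) for antiproliferative activity, read by MTT assay, with a stated time of 48 h (on this read-out lower numbers stand for stronger inhibition and higher numbers for weaker inhibition), compound 2 `CCN(CC)C/C1=C/C[C@](C)(CCC=C(C)C)/C=C/[C@@H](OC(=O)C=C(C)C)[C@](C)(O)/C=C/C1=O` gives 140 nM as the only exact number so far. Compound 1 `CC(C)=CCC[C@]1(C)/C=C/[C@@H](OC(=O)C=C(C)C)[C@](C)(O)/C=C/C(=O)/C(C(=O)O)=C\C1` is recorded only as a limit of > 10000 nM and not as a number.

The change to compound 3 `CC(C)=CCC[C@]1(C)/C=C/[C@@H](OC(=O)C=C(C)C)[C@](C)(O)/C=C/C(=O)/C(COC(=O)c2ccc([N+](=O)[O-])cc2)=C\C1` is ((4-nitrophenyl)carbonyl)oxy in place of diethylamino on a saturated chain carbon bound to a double-bonded ring carbon and amounts to ((4-nitrophenyl)carbonyl)oxy in place of diethylamino on a saturated chain carbon bound to a double-bonded ring carbon. Among the measured compounds shown here, one measured step bears on this: an at least 71-fold lower number from compound 1 to compound 2 (1.85 log units; beyond the scatter) with (diethylamino)methyl in place of carboxy on a double-bonded ring carbon. That large step shows that a swap in this part of the molecule can shift the result strongly in this assay but it does not test the group entering compound 3. The guide is therefore a loose one. Compound 3 gives up the diethylamino group that compound 2 carries, so a move towards weaker inhibition seems the more likely outcome, though probably not all the way to the limit. The expected step is an 8.6-fold higher number from compound 2 to compound 3 (0.93 log units; beyond the scatter) and its size is uncertain. Compound 3 is estimated at 1200 nM with an expected range of 200 nM to 8000 nM in this measurement.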

Compound 3, half-maximal inhibitory concentration: 830 nM
Compound 3: the middle estimate sits 1.4-fold (0.16 log units) above what was measured; the range from low to high includes it.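

In this assay, replacing the diethylamino group with ((4-nitrophenyl)carbonyl)oxy costs some strength but does not abolish the effect, with a 5.9-fold higher number from compound 2 to compound 3 (0.77 log units; beyond the scatter). This is the second exact number in the series, so the saturated chain carbon bound to a double-bonded ring carbon can carry more than one kind of group and still give a measurable result, even one as different as an entering group with an aromatic ring and no nitrogen bound directly to that carbon. The diethylamino group is therefore not the only group here that gives a measurable result, while compound 1, with its carboxy group directly on the double-bonded ring carbon, remains recorded as a limit and not as a number: the limit of > 10000 nM in this assay, at which 1 of the 3 values shown sits.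

The compounds shown leave open how a plain hydroxyl group or a ring amine such as piperidine would behave on this saturated chain carbon, which would help show how much of the step comes from losing diethylamino and how much from what replaces it. A plain benzoyloxy group would likewise show whether the nitro group on the aromatic ring plays any part in the result for compound 3.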